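A Phenyl for a Methyl on the Ring Nitrogen

The source may hold more compounds than are shown below. What is called first, only, known or untested is meant among the compounds shown, and "the series" means these compounds.

Three compounds set the scene in an ADME assay on RAW264.7 cells (Mus musculus) for cytotoxicity, read by trypan blue exclusion, with a stated time of 48 h; a lower number here means a stronger inhibitor of growth, a higher number a weaker inhibitor of growth. For compound 1 `Cc1c(CN2CCN(C3CC4CCC3C4)CC2)cc(-c2ccc(Cl)cc2)n1-c1ccc(Cl)cc1` the result is "not determined" (no result reported). Compound 2 `Cc1cc(CN2CCN(c3ccccc3)CC2)c(C)n1-c1ccc(Cl)cc1` gives 33 ug/mL, and compound 3 `Cc1c(CN2CCN(C)CC2)cc(-c2ccc(Cl)cc2)n1-c1ccc(Cl)cc1` gives 19 ug/mL, so compound 3 lies within the scatter of compound 2. Compound 4 `Cc1c(CN2CCN(c3ccccc3)CC2)cc(-c2ccc(Cl)cc2)n1-c1ccc(Cl)cc1` has phenyl in place of methyl on an amine nitrogen in a ring. For the measured compounds named here, no measured pair isolates this change in this assay. Compound 2, which carries phenyl there on a different core, gives 33 ug/mL, so only a small rise within the scatter is expected. The expected step runs a 1.3-fold higher number from compound 3 to compound 4 (0.12 log units; within the scatter). Compound 4 is estimated at 25 ug/mL, with an expected range of 10 ug/mL to 60 ug/mL.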

Compound 4, concentration for 50% growth inhibition: 175 ug/mL
Estimate against measurement, compound 4: 7.0-fold (0.85 log units) below; the measured number lies above the stated range.
By their numbers in this assay, from the lowest: compounds 3 and 2 (each within the scatter of the next); then compound 4.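

In this assay, for the compounds shown here, phenyl in place of methyl on an amine nitrogen in a ring gives a 9.2-fold higher number from compound 3 to compound 4 (0.96 log units; beyond the scatter), the first measured pair to isolate this change and a step beyond the scatter. With phenyl held at that nitrogen, 4-chlorophenyl in place of methyl on an aromatic carbon gives a 5.3-fold higher number from compound 2 to compound 4 (0.72 log units; beyond the scatter), so a second single change also raises the number beyond the scatter. Nothing available explains either step. From the compounds shown here alone, whether a benzyl or cyclohexyl group on that nitrogen would raise the number as far remains open, as does whether the phenyl step holds on another core.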